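Indoline nitrogen acylation and liver microsomal half-life

The compounds below may be only part of what the source reports. "The series", "measured", "known", "first", "only" and "open" are said of these compounds alone.

The measured compounds in an ADME assay on microsomes from liver (Homo sapiens) for metabolic stability (a lower number here means that the compound disappears faster, a higher number that the compound lasts longer), are:
compound 1 `Cc1cnc(Nc2ccc3c(c2)CCN3S(=O)(=O)c2ccc(C(F)(F)F)cc2)nc1-c1cnn(C)c1`, 0.122 h
compound 2 `CCCn1cc(-c2nc(Nc3ccc4c(c3)CCN4S(=O)(=O)c3ccc(C(F)(F)F)cc3)ncc2C)cn1`, 0.0397 h
compound 3 `N#CCCn1cc(-c2nc(Nc3ccc4c(c3)CCN4)ncc2F)cn1`, 0.0533 h

Compound 3 holds the second highest of the three numbers. Its value sits within the scatter of that of compound 2, so the two cannot be ranked; compound 1, the furthest, gives a higher number than compound 3, beyond the scatter. Compound 4 `N#CCCn1cc(-c2nc(Nc3ccc4c(c3)CCN4C(=O)c3ccc(C(F)(F)F)cc3)ncc2F)cn1` differs from compound 3 in one place: (4-(trifluoromethyl)phenyl)carbonyl in place of hydrogen on a nitrogen on an aromatic ring in a ring.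

Going by the values given here, no measured step covers this change. Among the compounds with values here, the only step recorded is a 3.1-fold lower number from compound 1 to compound 2 (0.49 log units; beyond the scatter), which concerns a chain on a different ring and shares with the present change only that both enlarge the molecule; it offers no direct guide. Compounds 1 and 2 carry a related substituent on the same nitrogen of the shared core and give short half-lives, as does compound 3 without it. Compound 4 is therefore expected to stay close to compound 3, with a 1.1-fold higher number from compound 3 to compound 4 (0.05 log units; within the scatter) lying within the scatter. The estimate for compound 4 in this assay is 0.06 h, with a range from 0.02 h to 0.18 h.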

Compound 4, half-life: 0.287 h
The estimate for compound 4 lay 4.8-fold (0.68 log units) below the measured number; measured number outside the range, above it.
By their numbers in this assay, from the lowest: compounds 2 and 3 (each within the scatter of the next); then compound 1; then compound 4.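

In this assay the nitrogen of the five-membered non-aromatic ring proves responsive: (4-(trifluoromethyl)phenyl)carbonyl in place of hydrogen there gives a 5.4-fold higher number from compound 3 to compound 4 (0.73 log units; beyond the scatter) and so lengthens the half-life. Going by these compounds alone, the only earlier step, a 3.1-fold lower number from compound 1 to compound 2 (0.49 log units; beyond the scatter) on a chain elsewhere in the molecule, also adds carbon atoms but moves the number the other way, so across these two steps adding heavy atoms has no single direction. Nothing among the data shown explains the rise at this nitrogen.

On these data alone, it remains open whether the gain belongs to the carbonyl or to the trifluoromethyl-bearing aromatic ring, a question that a plain benzoyl or an acetyl group on this nitrogen would address. As far as these compounds go, whether a simple alkyl group or a urea there would give a similar step is also open.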